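Trimming a Methyl from Sulfur: An Expected Small Change

The compounds below may be only part of what the source reports. "The series", "measured", "known", "first", "only" and "open" are said of these compounds alone.

Compound 3 `CSc1nccc2c1ncn2C1O[C@H](CO)[C@@H](O)[C@H]1O` was tested in a functional assay (Homo sapiens) for inhibition of Nucleic Acid, tested at 100 uM (a higher number here means more inhibition at the concentration tested (going by the name of the read-out), a lower number less inhibition), where compound 3 gives 24%. Compound 1 `OC[C@H]1O[C@@H](n2cnc3c(NCc4ccccc4)nccc32)C[C@@H]1O` gives 15%, a number within the scatter of compound 3, while compound 2 `CN(C)c1nccc2c1ncn2[C@H]1C[C@H](O)[C@@H](CO)O1` gives 0%, a number beyond the scatter below compound 3. Compound 4 `OC[C@H]1OC(n2cnc3c(S)nccc32)[C@H](O)[C@@H]1O` differs from compound 3 in one place: hydrogen in place of methyl on a sulfur. For the measured compounds named here, the only measured step, a number 15 percentage points lower from compound 1 to compound 2 (beyond the scatter), concerns an exchange of amine groups on an aromatic carbon rather than a change on sulfur, so it offers no direct guide here. With only the methyl leaving and a hydrogen entering, the expected step is a number 6 percentage points lower from compound 3 to compound 4 (within the scatter), not beyond the scatter. Compound 4 is therefore estimated at 18%, with a range from 2% to 38%.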

Compound 4, a percentage reported as inhibition, at one concentration (the size of the read-out at that concentration, not a potency): 6%
Compound 4: middle estimate off by 12 percentage points, on the high side, and the stated range covers the measured number.
By their numbers in this assay, from the lowest: compounds 2, 4, 1 and 3 (each within the scatter of the next, the first and the last beyond it).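

Hydrogen in place of methyl on a sulfur gives a number 18 percentage points lower from compound 3 to compound 4 (beyond the scatter) in this assay and is the first measured change at this sulfur. The earlier step concerned amine groups on an aromatic carbon, so only this result shows that removing a single carbon from the sulfur can move the number beyond the scatter. Nothing available explains why the number falls with this change. As far as these compounds go, what remains open is how a longer chain on the sulfur, such as ethyl or benzyl, would compare with methyl. A carboxylic acid carried on that chain is equally untested by the compounds shown here.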